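The compounds below may be only part of what the source reports. "The series", "measured", "known", "first", "only" and "open" are said of these compounds alone.

Two compounds share one core and differ only in the group on the aromatic ring. Compound 1 `O=C(CCCCCc1ccc(I)cc1)N1CCOC1=O` carries iodo there. In an assay on HEK293 cells for inhibition of N-acylethanolamine-hydrolyzing acid amidase (Rattus norvegicus), read by LC-MS, with a stated time of 30 min (on this read-out lower numbers stand for stronger inhibition and higher numbers for weaker inhibition), compound 1 reaches only the limit of the assay, > 20000 nM, so no number is known for it. Compound 2 `O=C(CCCCCc1ccc(C(F)(F)F)cc1)N1CCOC1=O` carries trifluoromethyl in the same place, and in this assay compound 2 gives 1040 nM. Going by the values given here, this is the only number measured so far; the other value shown is the limit of > 20000 nM in this assay, at which 1 of the 2 values shown sits. Among the compounds with values here, the step of an at least 19-fold lower number from compound 1 to compound 2 (1.28 log units; beyond the scatter) is therefore the one measured change of this group, and it is large. Compound 3 `Cc1ccc(CCCCCC(=O)N2CCOC2=O)cc1` has not been measured. It differs from compound 2 by methyl in place of trifluoromethyl on an aromatic carbon. Within the data shown here, the one measured step shows that exchanging the group at this place can move the number a great deal, but it ran from a limit to a number and gives no clear direction for methyl. A weakening beyond the scatter is expected, so that the step of a 2.9-fold higher number from compound 2 to compound 3 (0.46 log units; beyond the scatter) is estimated. For compound 3 the expected value in this assay is 3000 nM, with a range from 700 nM to 20000 nM.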

Compound 3, half-maximal inhibitory concentration: 440 nM
Estimate against measurement, compound 3: 6.8-fold (0.83 log units) above; the measured number lies below the stated range.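

Going by these compounds alone, at this place on the aromatic ring, replacing trifluoromethyl with methyl in this assay gives a 2.4-fold lower number from compound 2 to compound 3 (0.37 log units; beyond the scatter) and so provides the first step here with a true number at both ends. It is modest but beyond the usual scatter, and it shows that the smaller methyl, with one heavy atom against four, gives stronger inhibition than trifluoromethyl. From the compounds shown here alone, compound 1 stands at a limit of the assay and not at a number, so an at least 45-fold lower number from compound 1 to compound 3 (1.65 log units; beyond the scatter) tells only that iodo lags far behind methyl, and its true size stays unknown: the limit of > 20000 nM in this assay, at which 1 of the 3 values shown sits.

The three compounds rank methyl ahead of trifluoromethyl and trifluoromethyl ahead of iodo, but they cannot tell why the groups fall in this order, and three groups are too few to give a rule for this place. Going by these compounds, it stays open how a plain hydrogen, a methoxy group, an amine or a carboxylic acid would fare on this aromatic carbon, and whether a shorter or longer chain would keep the advantage of methyl.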